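A few compounds are considered here, and "the series" means these few. Any claim that something is new, unique, unknown or untested is made for them only; others in the source may bear on it.

compound 1 `Nc1nc(N)c2ncn(C3C=CC(CO)C3)c2n1`: > 100 ug/mL (a limit)
compound 2 `Nc1nc(Cl)c2nnn(C3C=CC(CO)C3)c2n1`: 1 ug/mL

Among the measured compounds shown here, in a functional assay on P388 cells (Mus musculus) for inhibition (a lower number here means that less compound is needed, a higher number that more compound is needed for the effect), compound 2 gives 1 ug/mL, the only actual number so far. Compound 1 stands at > 100 ug/mL, which is a limit and not a number.

Compound 3 `Nc1nc(O)c2nnn(C3C=CC(CO)C3)c2n1` carries hydroxy in place of chloro on an aromatic carbon. For the measured compounds named here, no measured step covers this exchange, so the expectation is loose: a moderate rise in the amount of compound needed is expected, an 8.0-fold higher number from compound 2 to compound 3 (0.90 log units; beyond the scatter), and no change beyond the scatter remains possible. For compound 3 the estimated value is 8 ug/mL, with an expected range from 1 ug/mL to 60 ug/mL.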

Compound 3, concentration for half-maximal effect: 4.5 ug/mL
Compound 3: the middle estimate sits 1.8-fold (0.25 log units) above what was measured; low and high end bracket the measured number.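

In this assay, among the compounds shown here, hydroxy in place of chloro on the aromatic carbon next to the ring nitrogen gives a 4.5-fold higher number from compound 2 to compound 3 (0.65 log units; beyond the scatter), the first measured step at this position. Compound 3 still gives a real number, 4.5 ug/mL, so this position tolerates hydroxy and chloro is not required for a measurable effect. Of the two groups, chloro needs less compound, and the step lies beyond the scatter.

Nothing at hand accounts for the size of this step. On these data alone, whether a methoxy group or a thiol on this carbon would fall nearer to chloro or to hydroxy stays open.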